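The source may report more compounds than this note shows. Statements on the series, on what has been measured and on what is new or still open speak of the compounds shown alone.

Of the compounds shown here, three of a shared core have been tested in a functional assay on HCT-116 cells (Homo sapiens) for inhibition, read by MTT assay, with a stated time of 2 days, tested at 10 uM; on this read-out higher numbers stand for more inhibition at the one concentration tested (going by the name of the read-out) and lower numbers for less inhibition. Compound 1 `COc1ccc(OC)c(-c2cn(-c3ccc(O)c(C(=O)Nc4cccc(C(F)(F)F)c4)c3)nn2)c1` gives 46%. Compound 2 `COC(=O)c1cc(-n2cc(-c3cc(OC)cc(OC)c3)nn2)ccc1O` gives 3%. Compound 3 `COc1ccc(-c2cn(-c3ccc(O)c(C(=O)O)c3)nn2)cc1` gives 8%, the second highest of the three numbers; its nearest neighbour is compound 2, whose value lies within the usual scatter of repeated measurements, while compound 1 stands far higher, beyond that scatter.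

The next compound, compound 4 `COc1ccc(-c2cn(-c3ccc(O)c(C(=O)OCCCc4ccccc4)c3)nn2)cc1`, differs from compound 3 in one place: 3-phenylpropyl in place of hydrogen on an oxygen next to a carbonyl group. Going by the values given here, no pair of measured compounds differing in only this way is available, so there is no measured step to lean on. Compound 2 carries a methyl group on the same oxygen and gives a low number, as does compound 3, so in this assay a step from the value of compound 3 of no more than modest size is expected, with no clear direction beyond the scatter. The step from compound 3 to compound 4 is expected to be a number 7 percentage points higher from compound 3 to compound 4 (within the scatter). Compound 4 is therefore estimated at 15%, within a range of 0% to 40%.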

Compound 4, a percentage reported as inhibition, at one concentration (the size of the read-out at that concentration, not a potency): 12%
For compound 4 the middle estimate is 3 percentage points above the measured one; low and high end bracket the measured number.
By their numbers in this assay, from the lowest: compounds 2, 3 and 4 (each within the scatter of the next); then compound 1.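

In this assay, going by these compounds alone, putting 3-phenylpropyl in place of hydrogen on an oxygen next to a carbonyl group gives a number 4 percentage points higher from compound 3 to compound 4 (within the scatter), the first measured step at this place. Earlier compounds offered only an indirect hint, whereas this pair isolates one change, and that change does not move the number beyond ordinary repeat variation. No independent measurement bears on this result.

Still open, from the compounds shown here alone, is whether a different group on this oxygen, such as a chain ending in an amine, would produce a step beyond the scatter. Also open, going by these compounds, is what would happen if an amine nitrogen replaced this oxygen while the rest of compound 3 stayed unchanged, since that single change would give an amide and could be read directly.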